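Swapping the halogenated ring on the oxadiazoline core

The compounds below may be only part of what the source reports. "The series", "measured", "known", "first", "only" and "open" are said of these compounds alone.

Of the compounds shown here, three sharing one core have been tested in a functional assay on PC-3 cells (Homo sapiens) for antiproliferative activity, read by MTT assay, tested at 5 uM; a higher number here means a stronger effect of the compound at the concentration tested, a lower number a weaker effect. Compound 1 `COc1ccc(OC)c(C2OC(c3cc(OC)c(OC)c(OC)c3)=NN2C(C)=O)c1` gives 43.2%, compound 2 `COc1cc(C2=NN(C(C)=O)C(c3ccccc3C(F)(F)F)O2)cc(OC)c1OC` gives 15.2%, and compound 3 `COc1cc(C2=NN(C(C)=O)C(c3ccc(F)cc3)O2)cc(OC)c1OC` gives 0.1%, the lowest of the three numbers, with the nearest being compound 2 and the furthest compound 1. The measured steps bearing on this group are a number 43.1 percentage points lower from compound 1 to compound 3 (beyond the scatter) and a number 15.1 percentage points lower from compound 2 to compound 3 (beyond the scatter), both beyond the scatter, showing that 4-fluorophenyl on this carbon gives the weakest of the three results. Compound 4 `COc1cc(C2=NN(C(C)=O)C(c3ccc(Cl)c(Cl)c3)O2)cc(OC)c1OC` is not yet measured; it differs from compound 3 by 3,4-dichlorophenyl in place of 4-fluorophenyl on a saturated ring carbon. Among the measured compounds shown here, no measured step covers 3,4-dichlorophenyl, so the expectation rests only on the fact that both other groups tried at this position gave higher numbers. Because a number 15.1 percentage points lower from compound 2 to compound 3 (beyond the scatter) is modest, a modest rise is expected, giving a number 11.9 percentage points higher from compound 3 to compound 4 (beyond the scatter) as the estimated step. Compound 4 is therefore expected to give about 12%, within a range from 0% to 35%.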

Compound 4, a percentage reported as inhibition, at one concentration (the size of the read-out at that concentration, not a potency): 26.1%
Compound 4: middle estimate off by 14.1 percentage points, on the low side, within the range that was stated.
By their numbers in this assay, from the lowest: compound 3; then compound 2; then compound 4; then compound 1.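

In this assay, 3,4-dichlorophenyl in place of 4-fluorophenyl gives a number 26 percentage points higher from compound 3 to compound 4 (beyond the scatter), so a halogen-bearing ring on this saturated ring carbon does not always give a reading as low as that of compound 3. The same group also outperforms the 2-(trifluoromethyl)phenyl ring, with a number 10.9 percentage points higher from compound 2 to compound 4 (beyond the scatter), which places the new ring above two of the three rings tried earlier. It still falls short of the 2,5-dimethoxyphenyl ring, with a number 17.1 percentage points lower from compound 1 to compound 4 (beyond the scatter), so compound 1 keeps the highest reading of the four, and the only ring here with oxygen-bearing substituents stays ahead of all the halogen-bearing ones.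

Still open, going by these compounds, is how a plain phenyl ring, or a ring carrying an amine or a carboxylic acid, would read at this position. Nothing available explains why the four rings fall in this order.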